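The source may report more compounds than this note shows. Statements on the series, on what has been measured and on what is new or still open speak of the compounds shown alone.

Working notes on the series.

Three compounds have a number in a physicochemical assay for lipophilicity, using the shake flask method, at pH 7.4; a higher number here means a more lipophilic compound, a lower number a more polar compound. Compound 1 `O=C(O)CCNC(=O)c1ccc(C(Oc2ccc(-n3cc(C(F)(F)F)cn3)cc2)C2CCCC2)cc1` gives 3.3, compound 3 `O=C(O)CCNC(=O)c1ccc(C(Oc2ccc(-n3cc(C(F)(F)F)cn3)cc2)C2CC2)cc1` gives 1.7, and compound 2 `CCCC(Oc1ccc(-n2cc(C(=O)N(C)C)cn2)cc1)c1ccc(C(=O)NCCC(=O)O)cc1` gives 0.5. Compound 2 thus stands lowest of the three, with compound 3 nearest and compound 1 furthest, both beyond the scatter. Compound 2 and compound 3 differ in two places at once, so their gap is read only as what the two values show.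

Compound 4 `CCCC(Oc1ccc(-n2cccn2)cc1)c1ccc(C(=O)NCCC(=O)O)cc1` is not yet measured. It differs from compound 2 in one place: hydrogen in place of dimethylcarbamoyl on an aromatic carbon

Within the data shown here, the one single-point step measured so far, a number 1.60 log units lower from compound 1 to compound 3 (beyond the scatter), concerns a different site and a different kind of group, so it does not speak directly to the present change; it only shows that single changes can move the distribution coefficient by a large amount. Among the measured compounds shown here, no measured pair addresses a carbamoyl leaving a pyrazole. Taking the step from compound 1 to compound 3 as a guide to the scale, a step upward beyond the scatter is expected, estimated as a number 1.20 log units higher from compound 2 to compound 4 (beyond the scatter). Compound 4 is therefore expected at about 1.7, in the range from 1 to 2.4.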

Compound 4, distribution coefficient: 1.7
Compound 4: middle estimate and measured number agree at the digits printed; measured number inside the range.
By their numbers in this assay, from the lowest: compound 2; then compounds 3 and 4 (each within the scatter of the next); then compound 1.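

Taking the dimethylcarbamoyl off the five-membered aromatic ring with 2 nitrogen and leaving hydrogen on that aromatic carbon gives, in this assay, a number 1.20 log units higher from compound 2 to compound 4 (beyond the scatter), so this position is now shown to carry a large step of its own, whereas the only earlier single-place step, a number 1.60 log units lower from compound 1 to compound 3 (beyond the scatter), lay at the saturated chain carbon. The group that leaves has 5 heavy atoms, among them 1 nitrogen and 1 oxygen, with 1 hydrogen-bond acceptor and no net charge, but this is one pair on one background, so the step cannot be shared out among those features. Nothing at hand gives a reason for the size of this step.

As far as these compounds go, whether a nitrile or an amine on this aromatic carbon would give a number nearer that of compound 2 or that of compound 4 stays open. From the compounds shown here alone, it is also open whether the same change would give a step of similar size with cyclopropyl or cyclopentyl on the saturated chain carbon, and compound 3 and compound 4 differ in two places, so that pair cannot isolate trifluoromethyl at this position.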